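From methoxy to trifluoromethoxy on a shared core

The source may report more compounds than this note shows. Statements on the series, on what has been measured and on what is new or still open speak of the compounds shown alone.

Three measured compounds share one core and differ in a single group on an aromatic carbon. Compound 1 `CC(C)(C)c1ccc(-n2nc(-c3ccc(C(F)(F)F)cc3O)nc2-c2ccccc2O)cc1` gives 77.8% in a functional assay on PC-12 cells (Rattus norvegicus) for cytotoxicity, read by MTT assay, with stated times of 2 h and 24 h, tested at 5 uM; a lower number here means a weaker effect, a higher number a stronger effect of the compound at the concentration tested. Compound 2 `Oc1cc(C(F)(F)F)ccc1-c1nc(-c2ccccc2O)n(-c2ccc(Br)cc2)n1` gives 89.8% in this assay, and compound 3 `COc1ccc(-n2nc(-c3ccc(C(F)(F)F)cc3O)nc2-c2ccccc2O)cc1` gives 86.6% in this assay. Compound 3 thus stands second highest of the three numbers, with compound 2 nearest and compound 1 furthest, both within the scatter of compound 3. The unmeasured compound 4 `Oc1cc(C(F)(F)F)ccc1-c1nc(-c2ccccc2O)n(-c2ccc(OC(F)(F)F)cc2)n1` differs from compound 3 by trifluoromethyl in place of methyl on an oxygen on an aromatic ring. Among the measured compounds shown here, the steps that bear on this exchange are those that swap the group at that same place: a number 12 percentage points higher from compound 1 to compound 2 (beyond the scatter), a number 8.8 percentage points higher from compound 1 to compound 3 (within the scatter) and a number 3.2 percentage points lower from compound 2 to compound 3 (within the scatter). Only the first of these reaches beyond the scatter, and all three measured values sit in a narrow band. In this assay the change is therefore expected to give a number 0.6 percentage points lower from compound 3 to compound 4 (within the scatter), nothing beyond the scatter. Compound 4 is estimated to give 86% in this assay, with a range from 74% to 95%.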

Compound 4, a percentage reported as activity, at one concentration (the size of the read-out at that concentration, not a potency): 84.9%
Beside the measured number, compound 4's estimate is 1.1 percentage points above it; the measured number falls inside the stated range.
By their numbers in this assay, from the lowest: compounds 1, 4, 3 and 2 (each within the scatter of the next, the first and the last beyond it).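

Trifluoromethyl in place of methyl on the oxygen leaves the read-out in this assay essentially unmoved, with a number 1.7 percentage points lower from compound 3 to compound 4 (within the scatter) as the whole of the exchange. Trifluoromethoxy also stays within the scatter of the other two groups at this place, with a number 4.9 percentage points lower from compound 2 to compound 4 (within the scatter) and a number 7.1 percentage points higher from compound 1 to compound 4 (within the scatter) as its steps, so unlike bromo it is not separated from tert-butyl in this assay. Nothing measured here accounts for these numbers.

What the compounds shown leave open is whether a group of a different kind at this place, such as an amine or a carboxylic acid, would stay close to these four values. On these data alone, all four carry the shared core, so whether the exchange of methoxy for trifluoromethoxy reads the same on another core also stays open.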